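A few compounds are considered here, and "the series" means these few. Any claim that something is new, unique, unknown or untested is made for them only; others in the source may bear on it.

Among the compounds with values here, compound 2, with the structure `CCCS(=O)(=O)Nc1ccc(F)c(C(=O)c2n[nH]c3ncc(-c4ccccc4C)cc23)c1F`, gives 7% in an assay for binding affinity to dual specificity mitogen-activated protein kinase kinase 4 (Homo sapiens), read by KINOMEscan, tested at 100 nM (on this read-out lower numbers stand for a stronger effect and higher numbers for a weaker effect at the one concentration tested), the lowest of the two numbers measured so far. Within the data shown here, its nearest neighbour is compound 1, with the structure `CCCS(=O)(=O)Nc1ccc(F)c(C(=O)c2n[nH]c3ncc(-c4cccc(Cl)c4)cc23)c1F`, which gives 40% in this assay; the single measured step, a number 33 percentage points lower from compound 1 to compound 2 (beyond the scatter), is the only change and it concerns the same aromatic ring that is now altered again. Compound 3, with the structure `CCCS(=O)(=O)Nc1ccc(F)c(C(=O)c2n[nH]c3ncc(-c4ccccc4O)cc23)c1F`, differs from compound 2 by hydroxy in place of methyl on an aromatic carbon. The measured step from compound 1 to compound 2 shows that a change on this ring can move the read-out by a large amount, but it swapped one group for another at a different place, so it does not tell in which direction a hydroxy in place of methyl will move the number. The estimate for compound 3 therefore stays near compound 2 but allows for a sizeable shift in either direction; the expected step is a number 13 percentage points higher from compound 2 to compound 3 (beyond the scatter). Compound 3 is expected to give about 20%, within a range from 3% to 60%.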

Compound 3, a percentage reported as activity, at one concentration (the size of the read-out at that concentration, not a potency): 9%
Compound 3: the middle estimate sits 11 percentage points above what was measured; low and high end bracket the measured number.
By their numbers in this assay, from the lowest: compounds 2 and 3 (each within the scatter of the next); then compound 1.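

Hydroxy in place of methyl on this aromatic carbon, ortho to a large group, gives a number 2 percentage points higher from compound 2 to compound 3 (within the scatter) in this assay and so leaves the read-out unmoved, even though the group that enters carries one hydrogen-bond donor and one hydrogen-bond acceptor and the group that leaves carries neither. The low number is therefore no longer tied to 2-methylphenyl alone: the step of a number 31 percentage points lower from compound 1 to compound 3 (beyond the scatter) for 2-hydroxyphenyl in place of 3-chlorophenyl runs the same way as the earlier step of a number 33 percentage points lower from compound 1 to compound 2 (beyond the scatter) and is likewise beyond the scatter. Nothing available here explains why methyl and hydroxy read alike at this place.

Because compound 1 differs from compound 2 and compound 3 in both the group and its place on the ring, these compounds do not separate the effect of the group from that of its place, and a chlorine on the same carbon ortho to a large group would be needed to do so. As far as these compounds go, how far this tolerance extends also remains open, for instance to an amine, a methoxy group or a carboxylic acid on that carbon.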